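The source may hold more compounds than are shown below. What is called first, only, known or untested is meant among the compounds shown, and "the series" means these compounds.

Compound 3, `O=C(O)c1csc(SCCN2C(=O)OC[C@@H]2/C=C/[C@@H](O)C2(CCCCF)CCC2)n1`, carries a 4-fluorobutyl chain on the shared core. In an assay on isolated protein for binding affinity to prostaglandin E2 receptor EP1 subtype (Homo sapiens) (a lower number here means a stronger inhibitor, a higher number a weaker inhibitor), compound 3 gives 1080 nM, the highest of the two numbers recorded so far; the nearest is compound 2, `CCCCC1([C@H](O)/C=C/[C@H]2COC(=O)N2CCSc2nc(C(=O)O)cs2)CCC1`, which in this assay gives 220 nM. Compound 1, `COCCCC1([C@H](O)/C=C/[C@H]2COC(=O)N2CCSc2nc(C(=O)O)cs2)CCC1`, returns in this assay only a limit of the assay, > 10000 nM. Among the measured steps, methyl in place of methoxy gave an at least 45-fold lower number from compound 1 to compound 2 (1.65 log units; beyond the scatter), fluoromethyl in place of methoxy gave an at least 9.2-fold lower number from compound 1 to compound 3 (0.96 log units; beyond the scatter), and fluoro in place of hydrogen gave a 4.9-fold higher number from compound 2 to compound 3 (0.69 log units; beyond the scatter). Compound 4, `CC#CCC1([C@H](O)/C=C/[C@H]2COC(=O)N2CCSc2nc(C(=O)O)cs2)CCC1`, differs from compound 3 by prop-1-yn-1-yl in place of 3-fluoropropyl on a saturated chain carbon bound to a saturated ring carbon. For the measured compounds named here, no measured step matches this change exactly. The closest guide is a 4.9-fold higher number from compound 2 to compound 3 (0.69 log units; beyond the scatter), a step in which a fluorine enters; in compound 4 the fluorine leaves again, while the triple bond is without precedent here. A modest step downward in this assay is therefore expected, a 3.6-fold lower number from compound 3 to compound 4 (0.56 log units; beyond the scatter). Compound 4 is estimated to give 300 nM in this assay, with a likely range from 90 nM to 1000 nM.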

Compound 4, inhibition constant: 89 nM
Beside the measured number, compound 4's estimate is 3.4-fold (0.53 log units) above it; the measured number lies below the stated range.
By their numbers in this assay, from the lowest: compound 4; then compound 2; then compound 3. At a limit, above all of these: compound 1.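

In this assay, on this saturated chain carbon bound to a saturated ring carbon, prop-1-yn-1-yl in place of propyl gives a 2.5-fold lower number from compound 2 to compound 4 (0.39 log units; beyond the scatter) and so moves the low end of the series past compound 2, which the saturated chains had not done. Prop-1-yn-1-yl in place of 3-fluoropropyl gives a 12-fold lower number from compound 3 to compound 4 (1.08 log units; beyond the scatter) and is the largest step among the compounds with full numbers, although it removes the fluorine and brings in the triple bond at once. Prop-1-yn-1-yl in place of 2-methoxyethyl gives an at least 110-fold lower number from compound 1 to compound 4 (2.05 log units; beyond the scatter) but that step starts from a limit of the assay and not from a number: (the limit of > 10000 nM in this assay, at which 1 of the 4 values shown sits).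

The compounds shown leave open whether a but-2-en-1-yl chain, with a double bond in place of the triple bond, would keep this gain. Also open, from the compounds shown here alone, is how a longer pent-2-yn-1-yl chain would read.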